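A few compounds are considered here, and "the series" means these few. Any claim that something is new, unique, unknown or untested is made for them only; others in the source may bear on it.

Compound 2 `CN1CCN(/N=C/c2c(-c3ccccc3)n(S(=O)(=O)c3ccc(F)cc3)c3ccccc23)CC1` gives 2900 nM in a functional assay on HEK293 cells for antagonist activity at 5-hydroxytryptamine receptor 6 (Homo sapiens), read by cAMP accumulation, with stated times of 10 min and 1 h; a lower number here means a stronger inhibitor, a higher number a weaker inhibitor; compound 1 `CN1CCN(/N=C/c2c(-c3ccccc3)n(S(=O)(=O)c3ccccc3)c3ccccc23)CC1` gives 1800 nM. Among the measured compounds shown here, the only step measured so far, a 1.6-fold higher number from compound 1 to compound 2 (0.21 log units; within the scatter), touches the aryl on the sulfonyl sulfur and stayed within the scatter. Compound 3 `CN1CCN(/N=C/c2c(-c3ccccc3)n(S(=O)(=O)c3cccc4ccccc34)c3ccccc23)CC1` differs from compound 2 by naphthalen-1-yl in place of 4-fluorophenyl on a sulfonyl sulfur. For the measured compounds named here, no measured step covers a change of this kind on the sulfonyl aryl; since the one measured change there gave nothing beyond the scatter, no step beyond the scatter is expected in this assay for compound 3. Compound 3 is estimated at 2500 nM, range 800 nM to 8000 nM, an expected step of a 1.2-fold lower number from compound 2 to compound 3 (0.06 log units; within the scatter).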

Compound 3, half-maximal inhibitory concentration: 6600 nM
The estimate for compound 3 lay 2.6-fold (0.42 log units) below the measured number; the measured number falls inside the stated range.
By their numbers in this assay, from the lowest: compounds 1 and 2 (each within the scatter of the next); then compound 3.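

In this assay, the sulfonyl aryl proves sensitive to a larger change: naphthalen-1-yl on the sulfonyl sulfur gives a weaker inhibitor than either 4-fluorophenyl (a 2.3-fold higher number from compound 2 to compound 3 (0.36 log units; beyond the scatter)) or phenyl (a 3.7-fold higher number from compound 1 to compound 3 (0.56 log units; beyond the scatter)). Fluoro in place of hydrogen had not separated compound 1 from compound 2, so this is the first change at this position to go beyond the scatter. No evidence on hand accounts for the shift.

As far as these compounds go, it remains open whether a naphthalen-2-yl or a pyridyl group on the sulfonyl sulfur would give a number closer to compound 1 or to compound 3.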